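Hydrazone Substituent Change on a Triazolylthioacetyl Scaffold

The source may hold more compounds than are shown below. What is called first, only, known or untested is meant among the compounds shown, and "the series" means these compounds.

Compound 1 `Brc1cccc(CSc2nnc(-c3ccncc3)n2-c2ccccc2)c1` in a functional assay on HepG2 cells (Homo sapiens) for inhibition, read by MTT assay, with a stated time of 48 h; on this read-out lower numbers stand for stronger inhibition and higher numbers for weaker inhibition: 7040 nM
Compound 2 `Clc1ccc(CSc2nnc(-c3ccncc3)n2-c2ccccc2)cc1` in this assay: 16900 nM
Compound 3 `O=C(CSc1nnc(-c2ccncc2)n1-c1ccccc1)N/N=C/c1ccc(Br)cc1` in this assay: 5990 nM

The three measured compounds share one core, with the group on the sulfur-bound chain varied. Compound 3 gives the lowest number of the three in this assay, though its gap to compound 1 lies within the scatter; only compound 2 sits clearly apart from it. Going by the values given here, the single measured step, a 2.4-fold higher number from compound 1 to compound 2 (0.38 log units; beyond the scatter), concerns the benzyl group and not the hydrazone part that is varied next, so it gives only a faint guide to how large an aryl change on this chain can be.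

Compound 4 `O=C(CSc1nnc(-c2ccncc2)n1-c1ccccc1)N/N=C/c1ccc(O)c(O)c1` differs from compound 3 by 3,4-dihydroxyphenyl in place of 4-bromophenyl on a carbon with a double bond to nitrogen. Among the compounds with values here, no measured pair shows this kind of change, so the direction is uncertain. Compound 4 is therefore expected to give a number close to that of compound 3, with a step of a 1.3-fold higher number from compound 3 to compound 4 (0.13 log units; within the scatter), and the estimate for compound 4 in this assay is 8000 nM, with a range from 2500 nM to 25000 nM.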

Compound 4, half-maximal inhibitory concentration: 16900 nM
For compound 4 the middle estimate is 2.1-fold (0.32 log units) below the measured one; measured number inside the range.
By their numbers in this assay, from the lowest: compounds 3 and 1 (each within the scatter of the next); then compounds 2 and 4 (each within the scatter of the next).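

Going by these compounds alone, the exchange of 4-bromophenyl for 3,4-dihydroxyphenyl gives a 2.8-fold higher number from compound 3 to compound 4 (0.45 log units; beyond the scatter) in this assay and so provides the first measured step on the hydrazone part of the series. It shows that the aryl group on a carbon with a double bond to nitrogen can shift the number beyond the scatter, and that this exchange moves it toward weaker inhibition. Nothing available here accounts for this shift.

The compounds shown leave open whether the shift follows from losing the bromine or from gaining the two hydroxyl groups, as no hydrazone with an unsubstituted phenyl or a single hydroxyl is among them. On these data alone, how a methoxy group, a nitro group or a dimethylamino group on this phenyl ring would read also remains open.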